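The source may report more compounds than this note shows. Statements on the series, on what has been measured and on what is new or still open speak of the compounds shown alone.

Series notes. Compound 1 `CCN(CC)c1cc2[nH]c(C3CCCCC3)nc2cc1NC(=O)OCCOCCOC` sits at the cytotoxicity ceiling in an ADME assay on Vero cells (Chlorocebus sabaeus) for cytotoxicity, read by resazurin assay, with a stated time of 3 days; a higher number here means a weaker inhibitor, a lower number a stronger inhibitor: in that assay compound 1 gives > 100 ug/mL, which is a limit of the assay and not a number. For the measured compounds named here, compound 2 `CN(C)c1cc2[nH]c(C3CCCCC3)nc2cc1NC(=O)c1ccco1` is the only other member measured; in this assay compound 2 gives > 100 ug/mL, again a limit and not a number. Going by the values given here, both measured values therefore rest at the limit of > 100 ug/mL in this assay, at which 2 of the 2 values shown sit, so no step between measured compounds is available, and compound 1 cannot be placed relative to compound 2 beyond the shared limit. Compound 3 `CCN(CC)c1cc2[nH]c(C3CCCCC3)nc2cc1NC(=O)c1ccc(F)cc1` is not yet measured. It differs from compound 1 by 4-fluorophenyl in place of 2-(2-methoxyethoxy)ethoxy on a carbonyl carbon. With nothing measured to draw on, no step beyond the scatter is expected in this assay in either direction. The expected step is a number no higher from compound 1 to compound 3 (the limit leaves the size open), meaning none beyond the scatter. Compound 3 is accordingly estimated at 100 ug/mL, within a range of 50 ug/mL to 200 ug/mL, and the assay is expected most likely to report only a limit again.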

Compound 3, half-maximal inhibitory concentration: > 100 ug/mL
Compound 3: no number, only a limit; the forecaster's own chance of this, stated with the estimate: 80%; the middle value lies on the limit itself.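

In this assay compound 3 gives > 100 ug/mL as a limit and not a number. For the compounds shown here, no step from compound 1 to compound 3 can therefore be read: the limit of > 100 ug/mL in this assay, at which 3 of the 3 values shown sit. The compounds shown leave open where any of the three would give an actual number in this read-out.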